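Ethyl Gives Way to Nitro on the Aromatic Ring

The source may report more compounds than this note shows. Statements on the series, on what has been measured and on what is new or still open speak of the compounds shown alone.

Compound 1 `CCc1ccccc1-c1nc(N)nc(N)n1`: 20%
Compound 2 `Nc1nc(N)nc(-c2cc(F)ccc2Cl)n1`: 78%

Two compounds have been run in a functional assay on the whole organism with Rattus norvegicus as the target, at a dose of 20 mg/kg by the intraperitoneal route; on this read-out higher numbers stand for more inhibition at the one dose given (going by the name of the read-out) and lower numbers for less inhibition. Compound 1 gives 20%, the lowest of the two numbers; its nearest neighbour, compound 2, gives 78%, a value beyond the usual scatter above it. Those two differ in more than one place, so their gap says only what the two values show. Compound 3 `Nc1nc(N)nc(-c2ccccc2[N+](=O)[O-])n1` has not yet been measured. It differs from compound 1 by a single change: nitro in place of ethyl on an aromatic carbon. Going by the values given here, no measured pair shows this change, so the step carries no precedent. Because compound 1 sits at 20% while compound 2 reaches 78%, the expected step in this assay is a rise, a number 25 percentage points higher from compound 1 to compound 3 (beyond the scatter), with wide uncertainty. Compound 3 is thus expected to give 45%, between 15% and 75%.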

Compound 3, a percentage reported as inhibition, in the whole organism at one dose (the size of the read-out at that dose, not a potency): 11%
Compound 3: the middle estimate sits 34 percentage points above what was measured; the measured number lies below the stated range.
By their numbers in this assay, from the lowest: compounds 3 and 1 (each within the scatter of the next); then compound 2.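

In this assay, nitro in place of ethyl on an aromatic carbon, ortho to a group of 8 heavy atoms, gives a number 9 percentage points lower from compound 1 to compound 3 (within the scatter). At this position, then, the two groups cannot be told apart on this read-out, even though nitro brings 2 hydrogen-bond acceptors where ethyl has none. Nothing measured here accounts for this result.

The compounds shown leave open whether any group on this aromatic carbon would give a step beyond the scatter, for instance an amine, a carboxylic acid or a methoxy group. They also leave open whether nitro in place of ethyl would give a similar step at another place on the ring.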